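Second trifluoromethyl on the same ring across two cores

This account rests on a few compounds, and the source may have more. Where it says the series, first, only, none or still open, it means among the compounds named here.

Compound 1 `CC(O)(CSc1cccc(C(F)(F)F)c1)C(=O)Nc1cccc(S(F)(F)(F)(F)F)c1` is measured in a functional assay on LNCaP cells (Homo sapiens) for antiproliferative activity, read by propidium iodide staining, with a stated time of 96 h (on this read-out higher numbers stand for weaker inhibition and lower numbers for stronger inhibition), where compound 1 gives 12700 nM. Compound 2 `CC(O)(CSc1cc(C(F)(F)F)cc(C(F)(F)F)c1)C(=O)Nc1cccc(S(F)(F)(F)(F)F)c1` differs from compound 1 in one place:

trifluoromethyl in place of hydrogen on an aromatic carbon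

In this assay compound 2 gives 4800 nM; the step is a 2.6-fold lower number from compound 1 to compound 2 (0.42 log units; beyond the scatter).

Compound 3 `CC(O)(CS(=O)(=O)c1cccc(C(F)(F)F)c1)C(=O)Nc1cccc(S(F)(F)(F)(F)F)c1` belongs to a second core; how that core differs from the core of compound 1 is not broken down here. In this assay compound 3 gives 21800 nM. The numbers of compound 3 and compound 1 lie within the usual scatter of each other, whereas the number of compound 2 is lower than that of compound 3 by more than the scatter.

Compound 4 `CC(O)(CS(=O)(=O)c1cc(C(F)(F)F)cc(C(F)(F)F)c1)C(=O)Nc1cccc(S(F)(F)(F)(F)F)c1`, not yet measured, differs from compound 3 in one place:

trifluoromethyl in place of hydrogen on an aromatic carbon

This is the same change as from compound 1 to compound 2, at a place described in identical words. The step from compound 3 to compound 4 is therefore expected to be a 2.6-fold lower number from compound 3 to compound 4 (0.41 log units; beyond the scatter), resting on the measured step of a 2.6-fold lower number from compound 1 to compound 2 (0.42 log units; beyond the scatter). Compound 4 is estimated at 8500 nM in this assay, with an expected range from 4000 nM to 19000 nM.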

Compound 4, half-maximal inhibitory concentration: 9700 nM
Compound 4: the middle estimate sits 1.1-fold (0.06 log units) below what was measured; measured number inside the range.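

In this assay the added trifluoromethyl gives a 2.2-fold lower number from compound 3 to compound 4 (0.35 log units; beyond the scatter), so the step seen on the core of compound 1 recurs on the core of compound 3. The two steps agree in size: the same change on two cores in this assay, a 2.6-fold lower number (0.42 log units; beyond the scatter) from compound 1 to compound 2 and a 2.2-fold lower number (0.35 log units; beyond the scatter) from compound 3 to compound 4, 1.2-fold (0.07 log units) apart, within the scatter of two such steps

Among the compounds shown here, this supports carrying this one change between these two cores in this cell read-out, but it rests on only two matched pairs, so it does not show that the step would hold on any further core, and the numbers alone give no reason for the lower values.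

The compounds shown leave open whether a different group at the same place, such as a nitrile, a chlorine atom or an amine, would give a step of similar size. Also open, going by these compounds, is whether the trifluoromethyl step would persist on a core carrying a sulfoxide, or on one with a carboxylic acid on the anilide ring.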